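The compounds below may be only part of what the source reports. "The series", "measured", "known", "first", "only" and "open" are said of these compounds alone.

Notes on the series. The shared core is seen in compound 1 `Cc1ccc(-c2n[nH]c3c2CCNCC3)cc1`, compound 2 `Fc1ccc(-c2n[nH]c3c2CCNCC3)cc1` and compound 3 `Cc1ccc(-c2noc3c2CCNCC3)cc1`. In an assay on cells for displacement of a labelled ligand from 5-hydroxytryptamine receptor 4 (Homo sapiens), read by scintillation counting, with a stated time of 1.5 h (on this read-out lower numbers stand for stronger inhibition and higher numbers for weaker inhibition), compound 1 gives only a limit, > 10000 nM. In this assay compound 2 likewise gives only a limit, > 10000 nM. In this assay compound 3 also gives only a limit, > 10000 nM. Within the data shown here, the step that the two limits leave unreadable from compound 1 to compound 2 is therefore unreadable, since the limit of > 10000 nM in this assay, at which 3 of the 3 values shown sit, covers every value so far. Compound 4 `Clc1ccc(-c2n[nH]c3c2CCNCC3)cc1` differs from compound 2 by chloro in place of fluoro on an aromatic carbon. Among the measured compounds shown here, no measured step bears readably on this change, and with every value at the limit, compound 4 is expected to remain at the limit as well, the step that the limit leaves unreadable from compound 2 to compound 4 being expected to stay unreadable. Compound 4 is estimated at 20000 nM, with a range from 8000 nM to 60000 nM.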

Compound 4, inhibition constant: > 10000 nM
Compound 4 gave a limit, no number; the forecaster's own chance of this, stated with the estimate: 85%; the middle value lies beyond the limit too.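

The steps from compound 1 and compound 2 to compound 4 cannot be read, because every value is only a limit: the limit of > 10000 nM in this assay, at which 4 of the 4 values shown sit.

The compounds shown leave open how the methyl, fluoro and chloro compounds rank, and whether any change to the shared core gives a readable value.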